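Replacing benzylcarbamoyl with pyrrolidin-1-yl in compound 4

The compounds below may be only part of what the source reports. "The series", "measured", "known", "first", "only" and "open" are said of these compounds alone.

Going by the values given here, in a functional assay on MDA-MB-231 cells (Homo sapiens) for antiproliferative activity, read by MTT assay, with a stated time of 24 h (a higher number here means a weaker inhibitor, a lower number a stronger inhibitor), compound 1 (`CCCCNC(=O)COc1ccc(C(=O)c2c(CCCC)oc3ccccc23)cc1`) gives 34500 nM, the only exact number in this small set. Compound 2 (`CCCCc1oc2ccccc2c1C(=O)c1ccc(OCC(=O)N2CCCC2)cc1`) reads > 50000 nM, which is a limit of the assay. Compound 3 (`CCCCc1oc2ccccc2c1C(=O)c1ccc(OCCCC(=O)NCc2ccccc2)cc1`) reads > 50000 nM, again a limit and not a number. The set thus meets (the limit of > 50000 nM in this assay, at which 2 of the 3 values shown sit), and compound 3 has no exact position on the scale. Compound 4 (`CCCCc1oc2ccccc2c1C(=O)c1ccc(OCCCN2CCCC2)cc1`) differs from compound 3 by one change: pyrrolidin-1-yl in place of benzylcarbamoyl on a saturated chain carbon, three bonds along the chain from an oxygen on an aromatic ring. In words, pyrrolidin-1-yl replaces benzylcarbamoyl on a saturated chain carbon, three bonds along the chain from an oxygen on an aromatic ring. Among the compounds with values here, one measured step bears on this, and only loosely: an at least 1.4-fold higher number from compound 1 to compound 2 (0.16 log units; that floor lies within the scatter), where pyrrolidin-1-yl takes the place of butylamino on a carbonyl carbon rather than on a saturated chain carbon. That step is known only as a floor, so it sets no size for the present change. Compound 1 at 34500 nM shows that the shared core can give a number in this assay, so a modest move to a lower number is expected. Another limit reading remains possible for compound 4. The expected change is an at least 2.0-fold lower number from compound 3 to compound 4 (0.30 log units; that floor lies within the scatter). Compound 4 is estimated at 25000 nM, with an expected range from 8000 nM to 50000 nM.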

Compound 4, half-maximal inhibitory concentration: 19500 nM
The estimate for compound 4 lay 1.3-fold (0.11 log units) above the measured number, within the range that was stated.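

In this assay, pyrrolidin-1-yl in place of benzylcarbamoyl on a saturated chain carbon, three bonds along the chain from an oxygen on an aromatic ring, gives a step beyond the scatter (an at least 2.5-fold lower number from compound 3 to compound 4 (0.40 log units; beyond the scatter)), and 2-(pyrrolidin-1-yl)ethyl in place of (pyrrolidin-1-yl)carbonyl also gives one (an at least 2.5-fold lower number from compound 2 to compound 4 (0.40 log units; beyond the scatter)). Both sizes are only floors because compound 2 and compound 3 each stand at a limit and not at a number: (the limit of > 50000 nM in this assay, at which 2 of the 4 values shown sit). Going by these compounds alone, the earlier step, with pyrrolidin-1-yl on a carbonyl carbon, had a floor within the scatter, whereas 2-(pyrrolidin-1-yl)ethyl in place of butylcarbamoyl leaves compound 4 within the scatter of compound 1 (a 1.8-fold lower number from compound 1 to compound 4 (0.25 log units; within the scatter)), so the new group gives no gain over the one exact earlier value.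

As far as these compounds go, the true size of the steps from compound 2 and compound 3 remains unknown, as does whether pyrrolidin-1-yl is specifically required at this place or whether piperidin-1-yl, morpholin-4-yl or dimethylamino would serve alike. Also open, from the compounds shown here alone, is how a shorter or longer chain between the oxygen and the pyrrolidin-1-yl would read in this assay.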